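Notes on a triazole series: cytotoxicity in HEK-293T cells

The compounds below may be only part of what the source reports. "The series", "measured", "known", "first", "only" and "open" are said of these compounds alone.

Measured compounds:
compound 1 `Cn1cc(SCc2nnc(SCc3ccccc3)n2-c2c(Cl)cccc2Cl)c2ccccc21`, > 100000 nM
compound 2 `Cn1cc(SCc2nnc(SCc3ccccc3Cl)n2-c2c(Cl)cccc2Cl)c2ccccc21`, 49600 nM
compound 3 `Cn1cc(SCc2nnc(SCc3cccc(Cl)c3Cl)n2-c2c(Cl)cccc2Cl)c2ccccc21`, > 100000 nM

Three analogues of one shared core have been tested in a toxicity assay on HEK-293T cells (Homo sapiens) for cytotoxicity, read by CCK-8 assay, with a stated time of 48 h; on this read-out higher numbers stand for lower toxicity in this test and lower numbers for higher toxicity in this test. Compound 1 gives only a limit of the assay, > 100000 nM. Compound 2 gives a number, 49600 nM. Compound 3 again returns a limit, > 100000 nM, so its standing is known only as a bound, not as a number. Of the steps, an at least 2.0-fold lower number from compound 1 to compound 2 (0.30 log units; that floor lies within the scatter) and an at least 2.0-fold higher number from compound 2 to compound 3 (0.30 log units; that floor lies within the scatter) each touch the floor of the scatter, while a step that the two limits leave unreadable from compound 1 to compound 3, as the limit of > 100000 nM in this assay, at which 2 of the 3 values shown sit, shows.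

Compound 4 `Cn1cc(SCc2nnc(SCc3cc(Cl)ccc3F)n2-c2c(Cl)cccc2Cl)c2ccccc21` is not yet measured. It differs from compound 3 by 5-chloro-2-fluorophenyl in place of 2,3-dichlorophenyl on a saturated chain carbon bound to a sulfur. Within the data shown here, none of the measured steps covers a swap of one halogen for another on this ring; the measured steps only show that adding or moving chlorines on it moved this assay little, and two of three values sit at the limit.

The expectation is therefore a step of a number no higher from compound 3 to compound 4 (the limit leaves the size open), that is, none beyond the scatter. Compound 4 is estimated at 100000 nM, with a range from 40000 nM to 250000 nM, and a fair chance that only a limit is reported.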

Compound 4, half-maximal cytotoxic concentration: > 100000 nM
Compound 4: only a limit was reported; the forecaster's own chance of this, stated with the estimate: 60%; the middle value lies on the limit itself.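

The new point is that a swap of halogens on this ring, 5-chloro-2-fluorophenyl in place of 2,3-dichlorophenyl, still yields no number in this assay, so a ring carrying fluorine joins the compounds that return only a limit. Among these compounds, the one readable step is an at least 2.0-fold higher number from compound 2 to compound 4 (0.30 log units; that floor lies within the scatter); this is only a floor, so it does not show compound 2 standing apart from compound 4 beyond the scatter. The steps to compound 4 from compound 1 and from compound 3 cannot be read, because both ends of each are limits: the limit of > 100000 nM in this assay, at which 3 of the 4 values shown sit.

Still open is how far the true values of compound 1, compound 3 and compound 4 lie beyond the limit, and so whether any of the halogen patterns shown truly differ in this assay. Also open, on these data alone, is whether a group of another kind, such as an amine or a carboxylic acid in place of 5-chloro-2-fluorophenyl on the saturated chain carbon bound to a sulfur, would give a clearly lower number.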